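This account rests on a few compounds, and the source may have more. Where it says the series, first, only, none or still open, it means among the compounds named here.

Among the measured compounds shown here, in an in vitro ADME assay on microsomes (Rattus norvegicus) for metabolic stability (a lower number here means that the compound disappears faster, a higher number that the compound lasts longer), compound 2 `CCc1nc(-c2ccc(Cl)cc2Cl)c(OC)nc1NC(CC)CC` gives 0.183 h and stands highest of the two numbers so far, while compound 1 `CCc1nc(-c2ccc(Cl)cc2Cl)c(CC)nc1NC(C1CC1)C1CC1` gives 0.0417 h and lies lower by more than the usual scatter. These two compounds differ in more than one place, so no single change can be read from their gap. Compound 3 `CCc1nc(-c2ccc(Cl)cc2Cl)c(CC)nc1NC(CC)CC` has ethyl in place of methoxy on an aromatic carbon and otherwise matches compound 2. Compound 1 also carries ethyl at that place and gives 0.0417 h in this assay but differs from compound 3 elsewhere, so it offers only a hint of direction. A modest fall is expected, with an estimated step of a 2.3-fold lower number from compound 2 to compound 3 (0.36 log units; beyond the scatter) towards a shorter half-life. Compound 3 is estimated at 0.08 h with a range of 0.035 h to 0.18 h as the expected span.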

Compound 3, half-life: 0.07 h
Estimate against measurement, compound 3: 1.1-fold (0.06 log units) above; the measured number falls inside the stated range.
By their numbers in this assay, from the lowest: compounds 1 and 3 (each within the scatter of the next); then compound 2.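

Among the compounds shown here, on the aromatic carbon next to the ring nitrogen, the first single-place comparison in this assay shows a shorter half-life with ethyl than with methoxy (a 2.6-fold lower number from compound 2 to compound 3 (0.42 log units; beyond the scatter)), with the pentan-3-yl group on the nitrogen held constant. With ethyl at that place, pentan-3-yl in place of dicyclopropylmethyl on the nitrogen gives a step within the scatter (a 1.7-fold higher number from compound 1 to compound 3 (0.22 log units; within the scatter)), so these two nitrogen substituents cannot be told apart here. Nothing available explains the shift between methoxy and ethyl.

On these data alone, it remains open whether methoxy would give a similar gap from ethyl with dicyclopropylmethyl on the nitrogen. The compounds shown also do not tell how an ethoxy group, a nitrile or a cyclopropyl group at the same place would compare with methoxy.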